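The source may hold more compounds than are shown below. What is called first, only, known or untested is meant among the compounds shown, and "the series" means these compounds.

Series in an ADME assay on J774.A1 cells (Mus musculus) for cytotoxicity; on this read-out lower numbers stand for higher toxicity in this test and higher numbers for lower toxicity in this test:
- Compound 1 `Fc1ccc(N2CCN(c3nc(-n4ccc5ccccc54)c4ccccc4n3)CC2)cc1`: 23.4 ug/mL
- Compound 2 `c1ccc2c(c1)ccn2-c1nc(N2CCNCC2)nc2ccccc12`: 3.11 ug/mL
- Compound 3 `CN1CCN(c2nc(-n3ccc4ccccc43)c3ccccc3n2)CC1`: 7.27 ug/mL

Of these three numbers, compound 3 at 7.27 ug/mL is the second highest. Compound 4 `c1ccc(N2CCN(c3nc(-n4ccc5ccccc54)c4ccccc4n3)CC2)nc1` has pyridin-2-yl in place of methyl on an amine nitrogen in a ring. The closest measured change at this nitrogen is a 3.2-fold lower number from compound 1 to compound 3 (0.51 log units; beyond the scatter), with methyl replacing 4-fluorophenyl. The other steps at this nitrogen are a 7.5-fold lower number from compound 1 to compound 2 (0.88 log units; beyond the scatter) and a 2.3-fold higher number from compound 2 to compound 3 (0.37 log units; beyond the scatter). Compound 4 again carries a six-membered aromatic ring there, so a change of similar size, opposite in direction to the first step, seems likely. The expected change is a 2.5-fold higher number from compound 3 to compound 4 (0.39 log units; beyond the scatter), a higher number and probably beyond the scatter. The estimate for compound 4 is 18 ug/mL, with an expected range of 8 ug/mL to 40 ug/mL.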

Compound 4, half-maximal cytotoxic concentration: 1.35 ug/mL
Estimate against measurement, compound 4: 13-fold (1.12 log units) above; the whole stated range lies above it.
By their numbers in this assay, from the lowest: compound 4; then compound 2; then compound 3; then compound 1.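

In this assay, a six-membered aromatic ring on this amine nitrogen does not settle the number: pyridin-2-yl in place of 4-fluorophenyl gives a 17-fold lower number from compound 1 to compound 4 (1.24 log units; beyond the scatter), the largest step in the set. Pyridin-2-yl also falls under both methyl and hydrogen, with a 5.4-fold lower number from compound 3 to compound 4 (0.73 log units; beyond the scatter) and a 2.3-fold lower number from compound 2 to compound 4 (0.36 log units; beyond the scatter), so the top rank held by 4-fluorophenyl does not extend to every aromatic ring at this position. Nothing measured here accounts for this reversal.

Open, as far as these compounds go, is where an unsubstituted phenyl or a pyridin-3-yl ring on this nitrogen would stand. Until then, the contributions of the fluorine and of the ring nitrogen cannot be told apart.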